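Swapping a fluorophenyl group for methyl on a brominated core

The source may hold more compounds than are shown below. What is called first, only, known or untested is meant among the compounds shown, and "the series" means these compounds.

Compound 1 `OC(CCn1nc2c(Br)c(Br)c(Br)c(Br)c2n1)c1ccc(F)cc1` — 109%
Compound 2 `COc1cccc(C(O)CCn2nc3c(Br)c(Br)c(Br)c(Br)c3n2)c1` — 97%
Compound 3 `C[C@@H](O)CCn1nc2c(Br)c(Br)c(Br)c(Br)c2n1` — 86%

In a functional assay on MCF7 cells (Homo sapiens) for antiproliferative activity, read by MTT assay, with a stated time of 48 h, tested at 12.5 uM (a lower number here means a stronger effect, a higher number a weaker effect of the compound at the concentration tested), compound 1 gives 109%, the highest of the three numbers, so the weakest effect seen here. Its nearest neighbour is compound 2, where a number 12 percentage points lower from compound 1 to compound 2 (beyond the scatter). Compound 3, whose value is 86%, lies furthest away. Compound 4 `CC(O)CCn1nc2c(Br)c(Br)c(Br)c(Br)c2n1` differs from compound 1 by methyl in place of 4-fluorophenyl on a saturated chain carbon bound to an oxygen on a saturated carbon and a saturated chain carbon. Among the compounds with values here, no measured step covers exactly this change, but compound 3 carries the same methyl group and shows a clearly lower number than compound 1. A downward step is therefore expected, a number 21 percentage points lower from compound 1 to compound 4 (beyond the scatter), and compound 4 is estimated at 88%, between 76% and 100%.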

Compound 4, a percentage reported as activity, at one concentration (the size of the read-out at that concentration, not a potency): 79%
Compound 4: the middle estimate sits 9 percentage points above what was measured; measured number inside the range.
By their numbers in this assay, from the lowest: compounds 4 and 3 (each within the scatter of the next); then compound 2; then compound 1.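

Methyl in place of 4-fluorophenyl gives a number 30 percentage points lower from compound 1 to compound 4 (beyond the scatter) and methyl in place of 3-methoxyphenyl gives a number 18 percentage points lower from compound 2 to compound 4 (beyond the scatter) in this assay so at this carbon, both compounds with an aromatic ring show a weaker effect than the methyl compound. The step of a number 7 percentage points lower from compound 3 to compound 4 (within the scatter) gives no sign that the drawn configuration matters here, and that pair differs in only one way: the fact that one of compounds 3 and 4 is drawn with a defined configuration and the other without, at the place where they differ.

On these data alone, what an amine, a carboxylic acid or a longer chain would give at this carbon stays open. So does the result for the methyl compound drawn with the S configuration.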